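The source may hold more compounds than are shown below. What is called first, only, known or untested is meant among the compounds shown, and "the series" means these compounds.

Measured compounds, all in a functional assay on HeLa cells (Homo sapiens) for inhibition, read by MTT assay, with a stated time of 48 h; a higher number here means a weaker inhibitor, a lower number a stronger inhibitor:

Compound 1 `CN1C(=O)CN(C2CCCC2)c2nc(Nc3ccc(N4CCCCC4)cn3)ncc21`: in this assay compound 1 gives > 30000 nM, which is a limit of the assay and not a number.
Compound 2 `CC1CCN(c2ccc(Nc3ncc4c(n3)N(C3CCCC3)CC(=O)N4C)nc2)CC1`: in this assay compound 2 gives > 30000 nM, again a limit.
Compound 3 `CCN1C(=O)CN(C2CCCC2)c2nc(Nc3ccc(N4CCCCC4)cc3)ncc21`: in this assay compound 3 gives > 30000 nM, again a limit.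

The change from compound 1 to compound 2 is methyl in place of hydrogen on a saturated ring carbon, and the step it made, a step that the two limits leave unreadable from compound 1 to compound 2, cannot be read, since (the limit of > 30000 nM in this assay, at which 3 of the 3 values shown sit). The difference between the core of compound 1 and the core of compound 3 is not broken down here. Compound 4 `CCN1C(=O)CN(C2CCCC2)c2nc(Nc3ccc(N4CCC(C)CC4)cc3)ncc21` has not yet been tested; it differs from compound 3 by methyl in place of hydrogen on a saturated ring carbon, the same change as from compound 1 to compound 2. For the measured compounds named here, because of the limit of > 30000 nM in this assay, at which 3 of the 3 values shown sit, no step is readable on which an expectation could rest. Compound 4 is therefore expected to sit at the limit as well, an estimated step of a number no higher from compound 3 to compound 4 (the limit leaves the size open) from compound 3. The estimate for compound 4 is 30000 nM, within 10000 nM to 100000 nM.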

Compound 4, half-maximal inhibitory concentration: > 30000 nM
Compound 4: only a limit was reported (the forecaster's own chance of this, stated with the estimate: 85%); the middle value sits exactly at the limit.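

No step can be read from compound 3 to compound 4, since both values are limits of the assay: the limit of > 30000 nM in this assay, at which 4 of the 4 values shown sit.
The compounds shown leave open whether piperidin-1-yl to 4-methylpiperidin-1-yl changes inhibition at all, and how strong any of these compounds is.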